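Ethyl for Trifluoromethyl on the Aryl of Compound 2

This account rests on a few compounds, and the source may have more. Where it says the series, first, only, none or still open, it means among the compounds named here.

Measured compounds:
compound 1 `O=C(O)CCc1ccc(OCc2ncc(-c3cccc(F)c3)o2)cc1` 1070 nM
compound 2 `O=C(O)CCc1ccc(OCc2nc(-c3ccc(C(F)(F)F)cc3)no2)cc1` 610 nM

In a functional assay on CHO cells for agonist activity at Free fatty acid receptor 1 (Homo sapiens), read by FLIPR and calcium flux, in the presence of a further agent that is not named here (on this read-out lower numbers stand for an effect already at smaller amounts and higher numbers for an effect only at larger amounts of compound), compound 2 gives the lower of the two numbers, with compound 1 nearest at a gap that lies within the scatter. Compound 3 `CCc1ccc(-c2noc(COc3ccc(CCC(=O)O)cc3)n2)cc1` is not yet measured. It differs from compound 2 by ethyl in place of trifluoromethyl on an aromatic carbon. Within the data shown here, no step between measured compounds bears on this change, so a step from compound 2 to compound 3 of a size within the scatter is expected in this assay, in no clear direction, a 1.2-fold lower number from compound 2 to compound 3 (0.09 log units; within the scatter). Compound 3 is estimated at 500 nM, within 150 nM to 2000 nM.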

Compound 3, half-maximal effective concentration: 210 nM
For compound 3 the middle estimate is 2.4-fold (0.38 log units) above the measured one; low and high end bracket the measured number.
By their numbers in this assay, from the lowest: compound 3; then compounds 2 and 1 (each within the scatter of the next).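

Among these compounds, the ring carbon para to a large group is the first place where a single change can be read: in this assay ethyl in place of trifluoromethyl gives a 2.9-fold lower number from compound 2 to compound 3 (0.46 log units; beyond the scatter) with fewer heavy atoms and no fluorine. The number at this position therefore responds to the group it carries, and trifluoromethyl is not required there for agonist activity. Nothing available accounts for the step. On these data alone, whether a longer chain such as propyl, or a methoxy group, would lower the number further stays open, as does whether the same exchange would act alike on another core.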